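Protein Binding Along a Piperidine Series, One Fluorine Added

The source may hold more compounds than are shown below. What is called first, only, known or untested is meant among the compounds shown, and "the series" means these compounds.

Measured compounds:
compound 1, `COc1ccc(F)cc1C1CCN(c2ccn3c(CC(F)(F)F)nnc3c2Cl)CC1` — < 0.01
compound 2, `COc1ccccc1C1CCN(c2ccn3c(CC4CC4)nnc3c2Cl)CC1` — < 0.01
compound 3, `COc1cccc(F)c1C1CCN(c2ccn3c(CC4CC4)nnc3c2Cl)CC1` — < 0.01

In an ADME assay on a cell-free system (plasma, Rattus norvegicus) for protein binding (a lower number here means a smaller unbound share, a higher number a larger unbound share of the compound), each of these three values is a limit of the assay rather than a number. Compound 3 therefore stands only at a limit, and the two other values shown are limits as well. The step that the two limits leave unreadable from compound 2 to compound 3 cannot be sized, because the limit of < 0.01 in this assay, at which 3 of the 3 values shown sit, holds both of its ends. Compound 4, `COc1c(C2CCN(c3ccn4c(CC5CC5)nnc4c3Cl)CC2)ccc(F)c1F`, is not yet measured; it differs from compound 3 by 3,4-difluoro-2-methoxyphenyl in place of 2-fluoro-6-methoxyphenyl on a saturated ring carbon. Among the measured compounds shown here, the only measured step that bears on this change is the one from compound 2 to compound 3, and its size is not readable, so no direction beyond the scatter can be expected for a step that the limit leaves unreadable from compound 3 to compound 4. Compound 4 is expected to sit at 0.005, with a range from 0.001 to 0.012, most likely reported again as a limit.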

Compound 4, unbound fraction: < 0.01
Compound 4: only a limit was reported; the forecaster's own chance of this, stated with the estimate: 85%; the middle value does not contradict the limit.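

In this assay compound 4 gives < 0.01 as a limit of the assay. Among the compounds shown here, no step among compound 2, compound 3 and compound 4 can be read, because all of them sit at the same limit: the limit of < 0.01 in this assay, at which 4 of the 4 values shown sit. The compounds shown leave open how large the unbound share of any of them actually is.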